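The source may report more compounds than this note shows. Statements on the series, on what has been measured and on what is new or still open speak of the compounds shown alone.

Of the compounds shown here, three have been measured in a functional assay on HCT-116 cells (Homo sapiens) for antiproliferative activity, read by MTT assay, with a stated time of 72 h; on this read-out lower numbers stand for stronger inhibition and higher numbers for weaker inhibition. Compound 1 `CCCC(=O)OC(C)c1nc([N+](=O)[O-])c(Sc2c(Cl)cncc2Cl)s1` gives 11700 nM, compound 2 `COc1ccc(Sc2sc(C(C)=O)nc2[N+](=O)[O-])cc1OC` gives 24000 nM, and compound 3 `O=C(Nc1ccccc1)c1nc([N+](=O)[O-])c(Sc2c(Cl)cncc2Cl)s1` gives 12400 nM. Compound 2 thus carries the highest of the three numbers; its value and that of compound 3 sit within the usual scatter of each other, while the gap to compound 1 lies beyond it. Compound 4 `COc1cccc(Sc2sc(C(C)=O)nc2[N+](=O)[O-])c1` differs from compound 2 in one place: hydrogen in place of methoxy on an aromatic carbon. For the measured compounds named here, no measured pair shows this change, so its effect cannot be read from the data. The expected step is no change at the digits printed from compound 2 to compound 4 (within the scatter), which is none beyond the scatter. Compound 4 is therefore expected to give 24000 nM in this assay, within a range from 10000 nM to 55000 nM.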

Compound 4, half-maximal inhibitory concentration: 17300 nM
Compound 4: middle estimate off by 1.4-fold (0.14 log units), on the high side; low and high end bracket the measured number.
By their numbers in this assay, from the lowest: compounds 1, 3, 4 and 2 (each within the scatter of the next, the first and the last beyond it).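

In this assay, for the compounds shown here, hydrogen in place of methoxy on an aromatic carbon, ortho to a methoxy group and para to a large group, gives a 1.4-fold lower number from compound 2 to compound 4 (0.14 log units; within the scatter) and so provides the first step that can be read. At this place, the loss of this methoxy group therefore moves the number by no more than the usual scatter. No evidence here bears on this result. From the compounds shown here alone, whether an amine or a carboxylic acid at this place would give a step beyond the scatter remains open. So does the effect of replacing the remaining methoxy group with hydrogen.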